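Cytotoxicity notes on the ether side-chain series

The compounds below may be only part of what the source reports. "The series", "measured", "known", "first", "only" and "open" are said of these compounds alone.

The series shares one core and varies the group on the ether oxygen. Compound 1 `CCC1(Cc2ccccc2)OS(=O)(=O)C=C1OCC#N` carries cyano there. In an ADME assay on HEL cells (Homo sapiens) for cytotoxicity, with a stated time of 3 days (on this read-out higher numbers stand for lower toxicity in this test and lower numbers for higher toxicity in this test), compound 1 reports only a limit, > 400000 nM. Compound 2 `CCC1(Cc2ccccc2)OS(=O)(=O)C=C1OCc1ccc(OC)cc1` carries 4-methoxyphenyl. In this assay compound 2 likewise reports a limit, >= 200000 nM. Compound 3 `CCC1(Cc2ccccc2)OS(=O)(=O)C=C1OCc1ccc([N+](=O)[O-])cc1` carries 4-nitrophenyl. In this assay compound 3 also gives no number but a limit, >= 80000 nM. Compound 3 thus stands on a limit, and the two further values shown are limits as well. The steps a step that the two limits leave unreadable from compound 1 to compound 2, a step that the two limits leave unreadable from compound 1 to compound 3 and a step that the two limits leave unreadable from compound 2 to compound 3 cannot be sized, each bounded on both ends by a limit.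

Compound 4 `CCC1(Cc2ccccc2)OS(=O)(=O)C=C1OCC=C(C)C` is not yet measured. Its change from compound 3: 2-methylprop-1-en-1-yl in place of 4-nitrophenyl on a saturated chain carbon bound to an oxygen on an unsaturated carbon. The steps a step that the two limits leave unreadable from compound 1 to compound 3 and a step that the two limits leave unreadable from compound 1 to compound 2 concern the same place, but neither gives a readable size, so no direction can be taken from them. The expectation is that the step that the limit leaves unreadable from compound 3 to compound 4 shows nothing beyond the scatter and that compound 4 again reaches only a limit. For compound 4 in this assay the estimate is 200000 nM, within 60000 nM to 500000 nM.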

Compound 4, minimum cytotoxic concentration: 400000 nM
Beside the measured number, compound 4's estimate is 2.0-fold (0.30 log units) below it; the measured number falls inside the stated range.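

In this assay, going by these compounds alone, compound 4 gives 400000 nM as a plain number and not a limit, the first such reading for a group on a saturated chain carbon bound to an oxygen on an unsaturated carbon. The change from 4-nitrophenyl to 2-methylprop-1-en-1-yl removes the aromatic ring and the hydrogen-bond acceptors of the leaving group, and a number of this size still results, so neither feature is required at this place for low toxicity in this test. The steps from compounds 1, 2 and 3 to compound 4 cannot be read in size, and only a number no higher from compound 1 to compound 4 (the limit leaves the size open) carries any direction.

With compounds 1, 2 and 3 resting on limits, no order among the four compounds can be given, and no group shown brings the read-out to a clearly lower number. Also open, on these data alone, is how a primary amine, a carboxylic acid or a longer saturated chain would read on this same carbon in this assay under the same conditions.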